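Methoxymethyl in place of oxan-4-yl on a carbonyl carbon

This account rests on a few compounds, and the source may have more. Where it says the series, first, only, none or still open, it means among the compounds named here.

Of the compounds shown here, two have been measured in an ADME assay on microsomes from liver (Mus musculus) for pharmacokinetics; on this read-out higher numbers stand for fast clearance and lower numbers for slow clearance. Compound 1 `C[C@H](NC(=O)CC(F)(F)F)c1ccc(NC(=O)[C@H]2C[C@@H]2c2cccnc2)cc1` gives 83.7 mL.min-1.g-1, and compound 2 `C[C@H](NC(=O)C1CCOCC1)c1ccc(NC(=O)[C@H]2C[C@@H]2c2cccnc2)cc1` gives 25.1 mL.min-1.g-1, the lower of the two numbers. Among the measured compounds shown here, the only measured step, a 3.3-fold lower number from compound 1 to compound 2 (0.52 log units; beyond the scatter), is modest but beyond the scatter. It replaces 2,2,2-trifluoroethyl with oxan-4-yl on a carbonyl carbon.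

Compound 3 `COCC(=O)N[C@@H](C)c1ccc(NC(=O)[C@H]2C[C@@H]2c2cccnc2)cc1` changes the same place again, while the rest of the structure stays as in compound 2: methoxymethyl in place of oxan-4-yl on a carbonyl carbon. For the measured compounds named here, no measured compound carries methoxymethyl, so the step to compound 1 sets a scale for a change at this place but does not predict this particular replacement. The size of that step, a 3.3-fold lower number from compound 1 to compound 2 (0.52 log units; beyond the scatter), is taken as a rough upper guide. With compound 2 at the low end of the two numbers in this assay, a small upward lean is more likely than a further fall. The estimated change is a 1.3-fold higher number from compound 2 to compound 3 (0.12 log units; within the scatter), which is expected to stay within the scatter. Compound 3 is expected at 33 mL.min-1.g-1, with an estimated range of 15 mL.min-1.g-1 to 70 mL.min-1.g-1.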

Compound 3, intrinsic clearance in microsomes: 43.2 mL.min-1.g-1
Compound 3: middle estimate off by 1.3-fold (0.12 log units), on the low side; low and high end bracket the measured number.
By their numbers in this assay, from the lowest: compounds 2, 3 and 1 (each within the scatter of the next, the first and the last beyond it).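

In this assay the step of a 1.7-fold higher number from compound 2 to compound 3 (0.24 log units; within the scatter) lies within the scatter, so replacing the oxan-4-yl ring with open-chain methoxymethyl on the carbonyl carbon gives no difference that can be resolved, and a ring at this place is not shown to be required for a number in this range. The step of a 1.9-fold lower number from compound 1 to compound 3 (0.29 log units; within the scatter) is also within the scatter, so methoxy in place of trifluoromethyl on the saturated chain carbon bound to the carbonyl carbon cannot be read as a real change either, and compound 3 cannot be separated from compound 1 or compound 2, even though those two stand apart by a 3.3-fold lower number from compound 1 to compound 2 (0.52 log units; beyond the scatter). Nothing available explains any of these numbers.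

As far as these compounds go, it remains open whether a tertiary amine, a carboxylic acid or a longer ether chain on this carbonyl carbon would take the number clearly outside the range set by these three compounds. From the compounds shown here alone, it also remains open whether a small ring such as oxetan-3-yl would stay with compound 2 or compound 3 or move nearer compound 1.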